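A few compounds are considered here, and "the series" means these few. Any claim that something is new, unique, unknown or untested is made for them only; others in the source may bear on it.

Measured in a functional assay on MCF7 cells (Homo sapiens) for antiproliferative activity; a higher number here means a weaker inhibitor, a lower number a stronger inhibitor:

- Compound 1 `CCNCCCOc1ccc2cc(NC(=O)c3ccc(O)c(CC=C(C)C)c3)c(=O)oc2c1C`: 980 nM
- Compound 2 `CCN(C)CCCOc1ccc2cc(NC(=O)c3ccc(O)c(CC=C(C)C)c3)c(=O)oc2c1C`: 2190 nM
- Compound 3 `CCN(CC)CCCOc1ccc2cc(NC(=O)c3ccc(O)c(CC=C(C)C)c3)c(=O)oc2c1C`: 6390 nM

Of the three, compound 3 has the highest number and is the weakest. Compound 4 `CC(C)=CCc1cc(C(=O)Nc2cc3ccc(OCCCNCC(C)C)c(C)c3oc2=O)ccc1O` differs from it as follows: isobutylamino in place of diethylamino on a saturated chain carbon, three bonds along the chain from an oxygen on an aromatic ring. Like compound 1, compound 4 keeps a hydrogen on the amine nitrogen. The closest measured step is a 6.5-fold higher number from compound 1 to compound 3 (0.81 log units; beyond the scatter), and the step of a 2.2-fold higher number from compound 1 to compound 2 (0.35 log units; beyond the scatter) points the same way. Read in reverse, these steps suggest a clearly lower number in this assay, though no measured compound carries isobutylamino. The expected change is a 4.0-fold lower number from compound 3 to compound 4 (0.60 log units; beyond the scatter). For compound 4 the estimated value is 1600 nM, with an expected range of 700 nM to 4000 nM.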

Compound 4, half-maximal inhibitory concentration: 1320 nM
Compound 4: the middle estimate sits 1.2-fold (0.08 log units) above what was measured, and the stated range covers the measured number.
By their numbers in this assay, from the lowest: compounds 1, 4 and 2 (each within the scatter of the next, the first and the last beyond it); then compound 3.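

In this assay the change from diethylamino to isobutylamino keeps the same atoms, joined differently, and still gives a 4.8-fold lower number from compound 3 to compound 4 (0.68 log units; beyond the scatter) in a step beyond the scatter, so at this position the arrangement of those atoms matters and not only their count. Set against the other two compounds, the picture is flatter: a 1.7-fold lower number from compound 2 to compound 4 (0.22 log units; within the scatter) and a 1.3-fold higher number from compound 1 to compound 4 (0.13 log units; within the scatter) both lie within the scatter, so isopropyl in place of methyl on the chain carbon bound to the amine nitrogen shows no measurable change.

As far as these compounds go, whether a piperidine or a tert-butylamino group on the same propyl chain would follow compound 4 remains open. Nothing available bears on why these steps differ.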